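The source may hold more compounds than are shown below. What is called first, only, known or untested is meant among the compounds shown, and "the series" means these compounds.

Working notes on a set of three compounds with one more to come.

Compound 1 `O=C1/C(=C/c2cccnc2)CN(S(=O)(=O)c2ccc(Cl)cc2)C/C1=C\c1ccccc1F` is the reference point: in a functional assay on HepG2 cells (Homo sapiens) for cytotoxicity, read by MTT assay, with a stated time of 24 h (a lower number here means a stronger inhibitor, a higher number a weaker inhibitor), compound 1 gives 12400 nM. Compound 2 `O=C1/C(=C/c2cccnc2)CN(S(=O)(=O)c2ccc(Br)cc2)C/C1=C\c1ccccc1F` keeps the same core and changes only the halogen, (bromo in place of chloro on an aromatic carbon); in this assay compound 2 gives 8700 nM, so the step is a 1.4-fold lower number from compound 1 to compound 2 (0.15 log units; within the scatter).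

Compound 3 `O=C1/C(=C/c2ccncc2)CN(S(=O)(=O)c2ccc(Cl)cc2)C/C1=C\c1ccccc1C(F)(F)F` has a different core; how the two cores differ is not broken down here. In this assay compound 3 gives 7190 nM, which sits with the other two numbers within the scatter, so no order among the three is claimed.

Compound 4 `O=C1/C(=C/c2ccncc2)CN(S(=O)(=O)c2ccc(Br)cc2)C/C1=C\c1ccccc1C(F)(F)F` is not yet measured. It differs from compound 3 by bromo in place of chloro on an aromatic carbon, the same change as from compound 1 to compound 2, at the same place. The expected step from compound 3 to compound 4 is a 1.2-fold lower number from compound 3 to compound 4 (0.08 log units; within the scatter), resting on the measured step of a 1.4-fold lower number from compound 1 to compound 2 (0.15 log units; within the scatter) on the first core, which was within the scatter. For compound 4 the estimate in this assay is therefore 6000 nM, with a range from 3000 nM to 12000 nM expected.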

Compound 4, half-maximal inhibitory concentration: 14500 nM
Compound 4: middle estimate off by 2.4-fold (0.38 log units), on the low side; measured number above the stated range.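

Bromo in place of chloro gives a 2.0-fold higher number from compound 3 to compound 4 (0.30 log units; within the scatter) in this assay, and set beside the earlier step, the same change does not read alike on the two cores: the same change on two cores in this assay, a 1.4-fold lower number (0.15 log units; within the scatter) from compound 1 to compound 2 and a 2.0-fold higher number (0.30 log units; within the scatter) from compound 3 to compound 4, 2.9-fold (0.46 log units) apart, beyond the scatter of two such steps. The step measured on the core of compound 1 therefore cannot be carried over as a fixed increment to the core of compound 3, at least for this pair of cores. This does not show which structural difference between the cores separates the two steps, and as each step alone lies within the scatter, neither halogen is shown to be better on either core.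

The compounds shown leave open how an amine or a carboxylic acid would read in this assay in place of the chloro or bromo on either core. Within the data shown here, with the change seen on only two cores, it also remains open whether a third core would follow either step.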